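Acylated amino acid amides of a shared nucleoside core

A few compounds are considered here, and "the series" means these few. Any claim that something is new, unique, unknown or untested is made for them only; others in the source may bear on it.

Measured so far:
compound 1, `CCCCCCCCCCCCCCCCCC(=O)N[C@@H](CCSC)C(=O)Nc1ccn([C@H]2O[C@@H](CO)[C@H](O)[C@H]2O)c(=O)n1`, gives 9000 nM in a functional assay on HeLa cells (Homo sapiens) for cytotoxicity, read by MTT assay, with a stated time of 48 h; on this read-out higher numbers stand for weaker inhibition and lower numbers for stronger inhibition
compound 2, `CCCCCCCCCC(=O)N[C@H](C(=O)Nc1ccn([C@H]2O[C@@H](CO)[C@H](O)[C@H]2O)c(=O)n1)C(C)C`, gives 4990 nM in this assay
compound 3, `CCCCCCCCCCCCCC(=O)N[C@@H](CCSC)C(=O)Nc1ccn([C@H]2O[C@@H](CO)[C@H](O)[C@H]2O)c(=O)n1`, gives 8020 nM in this assay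

Compound 1 holds the highest of the three numbers, but every gap to it is small: compound 3 is nearest, compound 2 furthest, and both differences fall within the scatter. For the measured compounds named here, the one single-point step measured so far, a 1.1-fold lower number from compound 1 to compound 3 (0.05 log units; within the scatter), shortens the acyl chain and leaves the read-out essentially unchanged.

Compound 4, `CCCCCCCCCCCCCCCCCC(=O)N[C@@H](CCC(=O)O)C(=O)Nc1ccn([C@H]2O[C@@H](CO)[C@H](O)[C@H]2O)c(=O)n1`, is the next one to be measured in this assay. Relative to compound 1 it carries carboxy in place of methylsulfanyl on a saturated chain carbon, three bonds along the chain from an amide-type nitrogen and a carbonyl carbon. Going by the values given here, no measured pair in the set alters this part of the molecule; the only step known concerns the acyl chain, so nothing in the data speaks directly to the change from methylsulfanyl to carboxy. The three compounds together sit in a narrow band, which suggests the series is not very sensitive to the variations examined so far.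

The expected step in this assay is therefore no change at the digits printed from compound 1 to compound 4 (within the scatter), i.e. nothing beyond the scatter in either direction. Compound 4 is estimated at 9000 nM, with a range from 3000 nM to 27000 nM.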

Compound 4, half-maximal inhibitory concentration: 19000 nM
Compound 4: middle estimate off by 2.1-fold (0.32 log units), on the low side, and the stated range covers the measured number.
By their numbers in this assay, from the lowest: compounds 2, 3 and 1 (each within the scatter of the next); then compound 4.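

In this assay, for the compounds shown here, this position gives the first single change that lies beyond the scatter: a 2.1-fold higher number from compound 1 to compound 4 (0.32 log units; beyond the scatter), with carboxy in place of methylsulfanyl on a saturated chain carbon, three bonds along the chain from an amide-type nitrogen and a carbonyl carbon. The direction is towards weaker inhibition, and the size is modest. Going by these compounds alone, the only other single-place step, a 1.1-fold lower number from compound 1 to compound 3 (0.05 log units; within the scatter), alters the acyl chain and stays within the scatter, which makes this side chain the one place so far where a change registers, though on a single pair; no measurement at hand accounts for the shift.

Open, from the compounds shown here alone, is whether the shift follows the carboxy group itself or the departure of methylsulfanyl, a question that an amine or a methyl ester on the same carbon would help to settle. Also open, going by these compounds, is whether the same exchange gives a similar step on the shorter acyl chain of compound 3, or on a longer chain than that of compound 1.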